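The compounds below may be only part of what the source reports. "The series", "measured", "known", "first", "only" and "open" are said of these compounds alone.

Going by the values given here, compound 2, `O=C(Nc1cc(Sc2ncn[nH]2)c(O)c2ccccc12)c1ccc(Cl)cc1`, is the one member of this small set that gives a number in a functional assay on PC-3 cells (Homo sapiens) for antiproliferative activity, read by MTT assay, with a stated time of 48 h; on this read-out higher numbers stand for weaker inhibition and lower numbers for stronger inhibition; in this assay compound 2 gives 5520 nM. Its partner compound 1, `O=C(Nc1cc(Sc2nncs2)c(O)c2ccccc12)c1ccc(Cl)cc1`, returns only a limit in this assay, > 100000 nM, which is the limit of > 100000 nM in this assay, at which 1 of the 2 values shown sits. Among the compounds with values here, the one measured step, an at least 18-fold lower number from compound 1 to compound 2 (1.25 log units; beyond the scatter), is therefore large and known only as a bound from the limit side.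

Compound 3, `Cn1nnnc1Sc1cc(NC(=O)c2ccc(Cl)cc2)c2ccccc2c1O`, differs from compound 2 in a single place: 1-methyl-1H-tetrazol-5-yl in place of 1H-1,2,4-triazol-5-yl on a sulfur. The ring that enters carries no hydrogen-bond donor, as the ring of compound 1 does not, whereas the ring of compound 2 carries one. Within the data shown here, the step from compound 1 to compound 2 is the only measured step that bears on this change, and it shows that swapping the ring on the sulfur can move the number in this assay by a large amount. With the donor gone again, a higher number is expected for compound 3 than for compound 2, a 5.4-fold higher number from compound 2 to compound 3 (0.74 log units; beyond the scatter). Compound 3 is accordingly estimated at 30000 nM, within 5000 nM to 150000 nM.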

Compound 3, half-maximal inhibitory concentration: > 100000 nM
Compound 3 was reported as a limit; the forecaster's own chance of this, stated with the estimate: 40%; middle value at least 3.3-fold (0.52 log units) from the limit.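

Going by these compounds alone, compound 2 now stands alone: it is the only one of the three compounds with a number in this assay, and the change on the sulfur gives an at least 18-fold higher number from compound 2 to compound 3 (1.25 log units; beyond the scatter), a large step known only as a bound. Among these three compounds, the 1H-1,2,4-triazol-5-yl of compound 2 is the only ring with a hydrogen-bond donor, and no compound here goes against the link between that donor and a measurable number, though three compounds cannot establish it as a general pattern. The step between compound 1 and compound 3 cannot be read, since both sit at the limit: the limit of > 100000 nM in this assay, at which 2 of the 3 values shown sit.

The change from compound 2 to compound 3 removes the donor but also adds a methyl group and alters the ring's hetero atoms, so the compounds shown do not tell which of these differences matters. From the compounds shown here alone, it remains open how the number in this assay would respond to a 1H-tetrazol-5-yl ring without the methyl on the same sulfur, which would separate the methyl group from the ring itself, or to a 1H-imidazol-2-yl ring there.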